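Series notes: one chloro removed from compound 3

A few compounds are considered here, and "the series" means these few. Any claim that something is new, unique, unknown or untested is made for them only; others in the source may bear on it.

Measured in a functional assay on U-87MG ATCC cells for antiproliferative activity against U-87 MG (Homo sapiens), read by MTT assay, with a stated time of 48 h; a lower number here means a stronger inhibitor, a higher number a weaker inhibitor:
compound 1 `COc1ccc(-c2nc(SCC(=O)c3sc(-c4ccccc4)nc3C)[nH]c(=O)c2C#N)cc1`: 48400 nM
compound 2 `Cc1nc(-c2ccc(Cl)cc2)sc1C(=O)CSc1nc(-c2ccc(Cl)cc2)c(C#N)c(=O)[nH]1`: 53000 nM
compound 3 `Cc1nc(-c2ccccc2)sc1C(=O)CSc1nc(-c2ccc(Cl)c(Cl)c2)c(C#N)c(=O)[nH]1`: 65000 nM

Compound 3 gives the highest of the three numbers, but its distance to compound 2 and to compound 1 lies within the scatter, so no order among the three can be read. Going by the values given here, the one measured step on the aryl attached to the shared core, a 1.3-fold higher number from compound 1 to compound 3 (0.13 log units; within the scatter), is also within the scatter. Compound 4 `Cc1nc(-c2ccccc2)sc1C(=O)CSc1nc(-c2ccc(Cl)cc2)c(C#N)c(=O)[nH]1` differs from compound 3 by hydrogen in place of chloro on an aromatic carbon. Among the compounds with values here, no measured step removes a single chloro; compound 2, which carries 4-chlorophenyl rather than 3,4-dichlorophenyl on the shared core, gives 53000 nM. Compound 4 is therefore expected to give 55000 nM, between 30000 nM and 100000 nM, the expected step of a 1.2-fold lower number from compound 3 to compound 4 (0.07 log units; within the scatter) lying within the scatter.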

Compound 4, half-maximal inhibitory concentration: 43400 nM
Beside the measured number, compound 4's estimate is 1.3-fold (0.10 log units) above it; measured number inside the range.
By their numbers in this assay, from the lowest: compounds 4, 1, 2 and 3 (each within the scatter of the next).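

In this assay, going from 3,4-dichlorophenyl to 4-chlorophenyl gives a 1.5-fold lower number from compound 3 to compound 4 (0.18 log units; within the scatter), so no effect of this chloro can be read at this position. Hydrogen in place of chloro on the other aryl gives a 1.2-fold lower number from compound 2 to compound 4 (0.09 log units; within the scatter), and chloro in place of methoxy gives a 1.1-fold lower number from compound 1 to compound 4 (0.05 log units; within the scatter), so all three single changes leave the series without a readable difference. No evidence at hand bears on this result.

Still open, going by these compounds, is whether an amine or a carboxylic acid on either aryl would give a step beyond the scatter.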